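Inversion at the chain carbon of compound 2

This account rests on a few compounds, and the source may have more. Where it says the series, first, only, none or still open, it means among the compounds named here.

The two measured compounds share one core and differ in what hangs from the ring nitrogen. Compound 1 `CC(C)Cn1c(=O)n(C)c(=O)c2cn(CC3Cc4ccccc4C3)cc21` gives 4.8 nM in a functional assay on Jurkat cells (Homo sapiens) for binding affinity, read by radioligand binding; a lower number here means a stronger inhibitor, a higher number a weaker inhibitor. Compound 2 `CC(C)Cn1c(=O)n(C)c(=O)c2cn([C@@H](C)c3ccccc3)cc21` gives 301 nM in this assay, the highest number of the two, with compound 1 standing far lower, beyond the scatter.

Compound 3 `CC(C)Cn1c(=O)n(C)c(=O)c2cn([C@H](C)c3ccccc3)cc21` is the next step. It differs from compound 2 as follows: the two compounds have the same atoms and bonds and differ only in configuration as drawn: 1 of 1 stereo elements differ; a stereocentre at a saturated chain carbon is drawn S in compound 2 and R in compound 3. Among the compounds with values here, no step between measured compounds of this kind is available, so the size is uncertain. Given that compound 1 reaches 4.8 nM on the same core, a lower number for compound 3 is expected, as a moderate step beyond the scatter, though a change in either direction cannot be excluded. Compound 3 is estimated at 60 nM in this assay, within 8 nM to 500 nM, an expected step of a 5.0-fold lower number from compound 2 to compound 3 (0.70 log units; beyond the scatter).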

Compound 3, inhibition constant: 562 nM
Beside the measured number, compound 3's estimate is 9.4-fold (0.97 log units) below it, outside the stated range (above it).
By their numbers in this assay, from the lowest: compound 1; then compounds 2 and 3 (each within the scatter of the next).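

In this assay, the chain carbon bearing the methyl and phenyl groups can now be compared in both drawn configurations, and the result is a 1.9-fold higher number from compound 2 to compound 3 (0.27 log units; within the scatter). Inverting this one stereocentre therefore gives no difference that can be told from the scatter, which compound 2 alone could not show. Nothing enters or leaves in this pair, so the comparison rests on the configuration at this carbon alone: the fact that compounds 2 and 3 differ only in the configuration as drawn.

The compounds shown leave open whether configuration at this carbon would still make no clear difference if an ethyl chain replaced the methyl or a pyridine ring replaced the phenyl. They also leave open which feature of the group on the ring nitrogen of compound 1 goes with its value of 4.8 nM.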